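This account rests on a few compounds, and the source may have more. Where it says the series, first, only, none or still open, it means among the compounds named here.

Measured to date:
- compound 1 `O=C(NCc1ccc(S(=O)(=O)c2ccccc2)cc1)N1Cc2cccnc2C1`: in an assay on isolated protein for inhibition of Nicotinamide phosphoribosyltransferase (Homo sapiens), read by mass spectrometry, with stated times of 15 min and 30 min (a higher number here means a weaker inhibitor, a lower number a stronger inhibitor), compound 1 gives 60 nM
- compound 2 `O=C(NCc1ccc(S(=O)(=O)C2CCOCC2)cc1)N1Cc2ccncc2C1`: compound 2 gives 26 nM
- compound 3 `CCC(=O)N1CCC(S(=O)(=O)c2ccc(CNC(=O)N3Cc4ccncc4C3)cc2)CC1`: compound 3 gives 27 nM

Compound 3 stands second highest of the three numbers in this assay; compound 2 sits within the scatter of it, while compound 1 shows the higher number of the set. The step to compound 4 `CN1CCN(S(=O)(=O)c2ccc(CNC(=O)N3Cc4ccncc4C3)cc2)CC1` is 4-methylpiperazin-1-yl in place of 1-propanoylpiperidin-4-yl on a sulfonyl sulfur. Within the data shown here, the only measured step at the same sulfonyl sulfur is a 1.0-fold higher number from compound 2 to compound 3 (0.02 log units; within the scatter), which was within the scatter. Among the measured compounds shown here, no measured step shows a change of this kind, so no shift beyond the scatter is expected in this assay: the step is estimated as a 1.1-fold higher number from compound 3 to compound 4 (0.05 log units; within the scatter). Compound 4 is expected at about 30 nM, in the range 12 nM to 75 nM.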

Compound 4, half-maximal inhibitory concentration: 38 nM
Beside the measured number, compound 4's estimate is 1.3-fold (0.10 log units) below it; the range from low to high includes it.
By their numbers in this assay, from the lowest: compounds 2, 3, 4 and 1 (each within the scatter of the next, the first and the last beyond it).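

In this assay, 4-methylpiperazin-1-yl on the sulfonyl sulfur stays within the scatter of both earlier groups, with a 1.4-fold higher number from compound 3 to compound 4 (0.15 log units; within the scatter) and a 1.5-fold higher number from compound 2 to compound 4 (0.16 log units; within the scatter) as the two steps. The entering group has fewer heavy atoms than 1-propanoylpiperidin-4-yl and no double bond outside aromatic rings, yet neither difference carries the number beyond the scatter. No supporting data bear on why these groups read alike. On these data alone, whether a carboxylic acid or a primary amine on this group, or a longer chain in place of its methyl, would move the number beyond the scatter remains open.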